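The source may report more compounds than this note shows. Statements on the series, on what has been measured and on what is new or still open speak of the compounds shown alone.

Measured compounds in an ADME assay on RAW264.7 cells (Mus musculus) for cytotoxicity, read by MTT assay, with a stated time of 48 h, tested at 50 uM; on this read-out higher numbers stand for more inhibition at the one concentration tested (going by the name of the read-out) and lower numbers for less inhibition:
compound 1 `N=C1S/C(=C\c2ccc(OCc3ccccc3)cc2)C(=O)N1c1ccc([N+](=O)[O-])cc1` — 17.3%
compound 2 `N=C1S/C(=C\c2ccc(OCc3ccccc3)cc2)C(=O)N1c1ccc(Cl)cc1Cl` — 13.8%
compound 3 `N=C1S/C(=C\c2ccc(OCc3ccccc3)cc2)C(=O)N1c1ccccc1` — 37.9%

Compound 2 gives the lowest of the three numbers in this assay; compound 1 sits nearest to it, a number 3.5 percentage points lower from compound 1 to compound 2 (within the scatter), and compound 3 furthest, a number 24.1 percentage points higher from compound 2 to compound 3 (beyond the scatter). Compound 1 and compound 3 differ from each other by a number 20.6 percentage points higher from compound 1 to compound 3 (beyond the scatter).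

The unmeasured compound 4 `Cc1ccc(N2C(=N)S/C(=C\c3ccc(OCc4ccccc4)cc3)C2=O)c(C)c1` shares the core of compound 2 and differs from it by 2,4-dimethylphenyl in place of 2,4-dichlorophenyl on an amide-type nitrogen in a ring.

For the measured compounds named here, two measured steps touch the same place. The change from compound 1 to compound 2, which swaps one substituted aryl group for another on the ring nitrogen, gives a number 3.5 percentage points lower from compound 1 to compound 2 (within the scatter). The change from compound 2 to compound 3, which removes both chlorines from that aryl group, gives a number 24.1 percentage points higher from compound 2 to compound 3 (beyond the scatter). The step to compound 4 keeps a substituted aryl group in place but exchanges 2,4-dichlorophenyl for 2,4-dimethylphenyl, so it resembles the first of these steps more than the second. A small rise in this assay is therefore expected, and the step of a number 6.2 percentage points higher from compound 2 to compound 4 (within the scatter) may well stay within the scatter.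

Compound 4 is expected to give about 20% in this assay, with a likely range from 8% to 36%.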

Compound 4, a percentage reported as inhibition, at one concentration (the size of the read-out at that concentration, not a potency): 36.8%
Beside the measured number, compound 4's estimate is 16.8 percentage points below it, outside the stated range (above it).
By their numbers in this assay, from the lowest: compounds 2 and 1 (each within the scatter of the next); then compounds 4 and 3 (each within the scatter of the next).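

In this assay, 2,4-dimethylphenyl in place of 2,4-dichlorophenyl on the amide-type nitrogen in a ring gives a number 23 percentage points higher from compound 2 to compound 4 (beyond the scatter), so carrying two substituents on this aryl group does not by itself keep the number low. The same position separates the two substituted groups in compound 4 and compound 1, with 2,4-dimethylphenyl in place of 4-nitrophenyl giving a number 19.5 percentage points higher from compound 1 to compound 4 (beyond the scatter), while the comparison with plain phenyl gives a number 1.1 percentage points lower from compound 3 to compound 4 (within the scatter). The four compounds therefore fall into two pairs, with the aryl groups bearing nitro or chlorine in compound 1 and compound 2 forming the low pair, and phenyl and 2,4-dimethylphenyl in compound 3 and compound 4 forming the high pair, and none of the four goes against this split.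

Going by these compounds, what separates the two pairs remains open, and nothing given here bears on it.

Also open, on these data alone, is whether the split would hold for an amine, a carboxylic acid or a methoxy group on this aryl group, or for a longer chain in the same place.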